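Carboxy in Place of 3-Fluorophenyl: Two Weak Inhibitors, One Estimate

The source may report more compounds than this note shows. Statements on the series, on what has been measured and on what is new or still open speak of the compounds shown alone.

Measured compounds:
compound 1 `Cc1n[nH]c(C(=O)O)c1Cc1cccc(-c2cccc(F)c2)c1`: 20%
compound 2 `Cc1n[nH]c(C(=O)O)c1Cc1ccccc1C(F)(F)F`: 13%

Both were tested in an assay on isolated protein for inhibition of 2-Hydroxyacid oxidase 2 (Homo sapiens), tested at 1 uM; a lower number here means a weaker effect, a higher number a stronger effect of the compound at the concentration tested. Compound 1 gives 20% and compound 2 gives 13%; compound 1 holds the larger of the two numbers, but the gap to compound 2 lies within the scatter, so the two are not distinguished. Compound 3 `Cc1n[nH]c(C(=O)O)c1Cc1cccc(C(=O)O)c1` has not been measured. It differs from compound 1 in one place: carboxy in place of 3-fluorophenyl on an aromatic carbon. Within the data shown here, no step between measured compounds covers this change. The expected step, a number 8 percentage points lower from compound 1 to compound 3 (within the scatter), is a slight decrease, not beyond the scatter. Compound 3 is estimated at 12%, within 0% to 28%.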

Compound 3, a percentage reported as inhibition, at one concentration (the size of the read-out at that concentration, not a potency): 3%
For compound 3 the middle estimate is 9 percentage points above the measured one; the range from low to high includes it.
By their numbers in this assay, from the lowest: compounds 3, 2 and 1 (each within the scatter of the next, the first and the last beyond it).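

In this assay, carboxy in place of 3-fluorophenyl on this aromatic carbon gives a number 17 percentage points lower from compound 1 to compound 3 (beyond the scatter). Among these compounds, this is the first step at this position, and it shows that the group held there can change the read-out, although the change is modest. No measurement shown here explains the step.

The compounds shown do not separate the loss of the 3-fluorophenyl ring from the entry of the carboxy group. Going by these compounds, it remains open how an unsubstituted phenyl, an amine or a methyl ester would read at this position.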